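Removing the Methoxy Group: Expected Cytotoxicity of Compound 3

This account rests on a few compounds, and the source may have more. Where it says the series, first, only, none or still open, it means among the compounds named here.

Compound 1 `COc1cc(O)c(C(=O)O)c(CCc2ccc3ccccc3c2)c1` carries a methoxy group on its core. Going by the values given here, in an ADME assay on HEK293 cells (Homo sapiens) for cytotoxicity, read by resazurin assay, with a stated time of 24 h (on this read-out lower numbers stand for higher toxicity in this test and higher numbers for lower toxicity in this test), compound 1 gives 65000 nM, the only actual number among the values shown. Compound 2 `Oc1cc(CCc2ccc3ccccc3c2)cc(O)c1O` lacks the methoxy group and the carboxy group and bears an additional hydroxy group. In this assay compound 2 gives > 100000 nM, which is a limit of the assay and not a number; it is the limit of > 100000 nM in this assay, at which 1 of the 2 values shown sits. Compound 3 `O=C(O)c1c(O)cccc1CCc1ccc2ccccc2c1` differs from compound 1 by hydrogen in place of methoxy on an aromatic carbon. Among the compounds with values here, no step between two measured compounds is available, and the limit of compound 2 fixes no size for this change. The step from compound 1 to compound 3 in this assay is expected to be small, a 1.2-fold higher number from compound 1 to compound 3 (0.06 log units; within the scatter), within the usual scatter or only slightly toward lower toxicity. Compound 3 is therefore estimated at 75000 nM, with a range from 30000 nM to 150000 nM.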

Compound 3, half-maximal cytotoxic concentration: > 100000 nM
Compound 3: no number, only a limit; the forecaster's own chance of this, stated with the estimate: 35%; middle value at least 1.3-fold (0.12 log units) from the limit.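

Hydrogen in place of methoxy on this aromatic carbon, para to a carboxy group, now has a step that can be read, though only as a floor: an at least 1.5-fold higher number from compound 1 to compound 3 (0.18 log units; that floor lies within the scatter). In this assay compound 3 gives > 100000 nM, which is a limit of the assay and not a number. The change therefore shows no move toward a lower number, but its true size stays unknown, and it may or may not exceed the scatter, because the values collect at the assay's limit: the limit of > 100000 nM in this assay, at which 2 of the 3 values shown sit.

The compounds shown leave open how an amine, a fluorine atom or a longer alkoxy chain on this carbon would compare with methoxy and hydrogen. They also leave open whether any group at this position would give a lower number than compound 1 does.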